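A few compounds are considered here, and "the series" means these few. Any claim that something is new, unique, unknown or untested is made for them only; others in the source may bear on it.

Measured in a functional assay on MGC-803 cells (Homo sapiens) for inhibition, read by sulforhodamine B assay; on this read-out lower numbers stand for stronger inhibition and higher numbers for weaker inhibition:

Compound 1 `Cc1ccc(NC2=CC(=O)c3nc4n(c3C2=O)[C@H]2OC[C@@H](O)[C@H]2OC4)cc1`: 1420 nM
Compound 2 `COc1cccc(NC2=CC(=O)c3nc4n(c3C2=O)[C@H]2OC[C@@H](O)[C@H]2OC4)c1`: 1780 nM

Among the measured compounds shown here, compound 2, at 1780 nM, lies within the scatter of compound 1, the only other measured compound, so the two cannot be ranked. Compound 3 `O=C1C=C(N2CCCC2)C(=O)c2c1nc1n2[C@H]2OC[C@@H](O)[C@H]2OC1` has not yet been measured in this assay. It differs from compound 2 as follows: pyrrolidin-1-yl in place of (3-methoxyphenyl)amino on a double-bonded ring carbon. In words, pyrrolidin-1-yl stands in place of (3-methoxyphenyl)amino on a double-bonded ring carbon.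

For the measured compounds named here, only one measured step bears on this change, and only indirectly. That step, a 1.3-fold higher number from compound 1 to compound 2 (0.10 log units; within the scatter), exchanges one substituted phenyl group on the amine nitrogen for another and stays within the scatter. Going by the values given here, no measured compound carries pyrrolidin-1-yl, so the data do not show what replacing the whole (3-methoxyphenyl)amino group does. A moderate move towards a higher number is therefore expected, held with little confidence, and a change in the other direction cannot be excluded. The expected change is a 1.7-fold higher number from compound 2 to compound 3 (0.23 log units; within the scatter). For compound 3 the estimated value is 3000 nM, with an expected range from 800 nM to 11000 nM.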

Compound 3, half-maximal inhibitory concentration: > 16000 nM
Compound 3: only a limit was reported (the forecaster's own chance of this, stated with the estimate: 7%); at least 5.3-fold (0.72 log units) between middle value and limit.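

In this assay, compound 3 gave only a limit and not a number: the limit of > 16000 nM in this assay, at which 1 of the 3 values shown sits.

The earlier step, a 1.3-fold higher number from compound 1 to compound 2 (0.10 log units; within the scatter), exchanged one substituted phenyl group on the amine nitrogen for another and stayed within the scatter, so it showed nothing about replacing the whole group. Pyrrolidin-1-yl in place of (3-methoxyphenyl)amino now gives an at least 8.9-fold higher number from compound 2 to compound 3 (0.95 log units; beyond the scatter), and in place of (4-methylphenyl)amino it gives an at least 11-fold higher number from compound 1 to compound 3 (1.05 log units; beyond the scatter). Going by these compounds, the group on this double-bonded ring carbon therefore matters to the read-out, with both steps beyond the scatter, although their full size stays unknown.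

The change removes the six-membered aromatic ring and the hydrogen-bond donor together, and compounds 1, 2 and 3 do not show which of the two losses, if either alone, accounts for the higher number. A cyclopentylamino group, which keeps the amine hydrogen without the aromatic ring, and an N-methyl-N-phenylamino group, which keeps the aromatic ring without the amine hydrogen, would pull these two apart.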